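Cytotoxicity notes on an oxadiazole-thioether hydrazone series

The source may hold more compounds than are shown below. What is called first, only, known or untested is meant among the compounds shown, and "the series" means these compounds.

Measured compounds:
compound 1, `COc1ccc(/C=N/NC(=O)CSc2nnc(-c3ccncc3)o2)cc1`, 132000 nM
compound 2, `O=C(CSc1nnc(-c2ccncc2)o1)N/N=C/c1ccccc1O`, 155000 nM

In an ADME assay on NIH3T3 cells (Mus musculus) for cytotoxicity, read by MTT assay, with a stated time of 24 h (on this read-out higher numbers stand for weaker inhibition and lower numbers for stronger inhibition), compound 1 gives 132000 nM and stands as the lower of the two numbers, with compound 2 nearest at 155000 nM. The step of a 1.2-fold higher number from compound 1 to compound 2 (0.07 log units; within the scatter) shows that exchanging the group on the carbon with a double bond to nitrogen leaves the read-out within the scatter.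

Compound 3, `O=C(CSc1nnc(-c2ccncc2)o1)N/N=C/c1cc(Cl)cc(Cl)c1O`, is not yet measured. Compared with compound 1 the change is 3,5-dichloro-2-hydroxyphenyl in place of 4-methoxyphenyl on a carbon with a double bond to nitrogen. Within the data shown here, the only measured step that bears on it is the one from compound 1 to compound 2, which was within the scatter; no measured pair covers the two chlorines. The expectation for this assay is therefore a step of at most modest size, with a slight lean toward a lower number, a 1.4-fold lower number from compound 1 to compound 3 (0.14 log units; within the scatter). Compound 3 is estimated at 95000 nM, with a range from 40000 nM to 230000 nM.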

Compound 3, half-maximal inhibitory concentration: 171000 nM
Beside the measured number, compound 3's estimate is 1.8-fold (0.26 log units) below it; the range from low to high includes it.
By their numbers in this assay, from the lowest: compounds 1, 2 and 3 (each within the scatter of the next).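

In this assay, the 3,5-dichloro-2-hydroxyphenyl group on a carbon with a double bond to nitrogen gives no step beyond the scatter against the 4-methoxyphenyl group (a 1.3-fold higher number from compound 1 to compound 3 (0.11 log units; within the scatter)). Adding the two chlorines to the 2-hydroxyphenyl group likewise stays within the scatter (a 1.1-fold higher number from compound 2 to compound 3 (0.04 log units; within the scatter)), so all three substituted phenyl groups at this position now give values that the read-out does not separate. No supporting measurement is available to explain this flat result.

On these data alone, whether an amine or a carboxylic acid in place of these phenyl groups would move the read-out beyond the scatter remains open. The compounds shown also leave open whether any change on the shared core, away from this position, would do so.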